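Three Inactive Analogs and a Fourth Awaiting Measurement

The source may report more compounds than this note shows. Statements on the series, on what has been measured and on what is new or still open speak of the compounds shown alone.

Compound 1 `COc1cccc(C(=O)Nc2cc(Sc3ncn[nH]3)c(O)c3ccccc23)c1` shows no measurable antiproliferative effect in a functional assay on HCT-116 cells (Homo sapiens) for antiproliferative activity, read by MTT assay, with a stated time of 48 h; on this read-out lower numbers stand for stronger inhibition and higher numbers for weaker inhibition: the value for compound 1 is only the limit of the test, > 100000 nM. Compound 2 `O=C(/C=C/c1ccc([N+](=O)[O-])cc1)Nc1cc(Sc2ncn[nH]2)c(O)c2ccccc12` likewise reaches only the limit, > 100000 nM. Compound 3 `COc1ccc(/C=C/C(=O)Nc2cc(Sc3ncn[nH]3)c(O)c3ccccc23)cc1OC` stands at the same place, giving only the limit, > 100000 nM. Within the data shown here, the single change among the measured compounds cannot be read as a step of any size: a step that the two limits leave unreadable from compound 2 to compound 3. All that the measured values offer is the limit of > 100000 nM in this assay, at which 3 of the 3 values shown sit. Compound 4 `O=C(/C=C/c1ccc(Cl)cc1)Nc1cc(Sc2ncn[nH]2)c(O)c2ccccc12` differs from compound 3 in one place: 4-chlorophenyl in place of 3,4-dimethoxyphenyl on a double-bonded chain carbon bound to a double-bonded chain carbon. Among the measured compounds shown here, no measured step gives a readable size for a change of this kind, so the expectation for compound 4 in this assay is simply that it stays with the three compounds already measured and does not come below the limit. Compound 4 is therefore estimated at 150000 nM, with a range from 30000 nM to 1000000 nM, and most probably again reported only as a limit. The expected step is a step that the limit leaves unreadable from compound 3 to compound 4, meaning no change beyond the scatter.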

Compound 4, half-maximal inhibitory concentration: > 100000 nM
Compound 4 ended at the assay's limit; the forecaster's own chance of this, stated with the estimate: 75%; the middle value does not contradict the limit.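

No step can be read among compound 1, compound 2, compound 3 and compound 4, as each value is only a limit: the limit of > 100000 nM in this assay, at which 4 of the 4 values shown sit.

The compounds shown leave open whether any change on the shared core gives a measurable value in this assay, and how large such a step would be.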